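The source may hold more compounds than are shown below. What is called first, only, known or untested is meant among the compounds shown, and "the series" means these compounds.

Of the compounds shown here, three share one core and have been tested in a functional assay on HCT-116 cells (Homo sapiens) for inhibition, read by MTT assay, with a stated time of 24 h, tested at 5 uM; on this read-out lower numbers stand for less inhibition of growth and higher numbers for more inhibition of growth at the one concentration tested. Compound 1 `O=c1c(-c2nnc(-c3ccc(F)cc3)o2)c[nH]c2ncc(-c3cccnc3)cc12` gives 11.1%. Compound 2 `O=c1c(-c2nnc(-c3ccc(Cl)cc3)o2)c[nH]c2ncc(-c3cccnc3)cc12` gives 15.9%. Compound 3 `CS(=O)(=O)c1ccc(-c2cnc3[nH]cc(-c4nnc(-c5ccc(Cl)cc5)o4)c(=O)c3c2)cc1` gives 16.4%. Compound 3 holds the highest of the three numbers, yet the step of a number 0.5 percentage points higher from compound 2 to compound 3 (within the scatter) is within the scatter and the gap to compound 1 is also within the scatter, so the three compounds cannot be told apart on these numbers.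

Compound 4 `CS(=O)(=O)c1ccc(-c2cnc3[nH]cc(-c4nnc(-c5cccnc5)o4)c(=O)c3c2)cc1` is the next compound. It differs from compound 3 in one place: pyridin-3-yl in place of 4-chlorophenyl on an aromatic carbon. The new group sits on a carbon of the five-membered aromatic ring with 2 nitrogen and 1 oxygen.

Among the measured compounds shown here, no measured step covers this exact exchange. For the measured compounds named here, the one step that touches the same group is a number 4.8 percentage points higher from compound 1 to compound 2 (within the scatter), which changed only the halogen on that ring and moved the read-out very little. The other step, a number 0.5 percentage points higher from compound 2 to compound 3 (within the scatter), concerns a different position. Both steps suggest that changes on the outer rings of this core barely move the read-out. For compound 4 the step of a number 2.4 percentage points lower from compound 3 to compound 4 (within the scatter) is therefore expected to stay within the scatter. Compound 4 is estimated to give 14%, with a range from 4% to 25%.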

Compound 4, percent growth inhibition at one concentration: 9.26%
Compound 4: middle estimate off by 4.7 percentage points, on the high side; the range from low to high includes it.
By their numbers in this assay, from the lowest: compounds 4, 1, 2 and 3 (each within the scatter of the next).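

In this assay, putting pyridin-3-yl in place of 4-chlorophenyl on the aromatic carbon of the five-membered aromatic ring with 2 nitrogen and 1 oxygen gives a number 7.1 percentage points lower from compound 3 to compound 4 (within the scatter). The earlier compounds shown here showed only one halogen exchanged for another on the outer ring at this position, whereas this step replaces the whole ring: a six-membered aromatic ring of carbon only gives way to one with 1 hetero atom and 1 hydrogen-bond acceptor, and even this larger change in structure stays within the scatter. No measurement shown here bears on what lies behind this result.

All four compounds shown carry a six-membered aromatic ring at this position, so it remains open how a group of a different kind, such as an amine, a carboxylic acid or a longer alkyl chain, would read out on this carbon. As far as these compounds go, it also remains open whether any change to the shared core can move growth inhibition beyond the scatter, and how these compounds would compare across a range of concentrations rather than at a single one.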